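A few compounds are considered here, and "the series" means these few. Any claim that something is new, unique, unknown or untested is made for them only; others in the source may bear on it.

Of the compounds shown here, three sharing one core have been tested in a functional assay on CFPAC-1 cells (Homo sapiens) for antiproliferative activity, read by MTT assay, with a stated time of 72 h; on this read-out lower numbers stand for stronger inhibition and higher numbers for weaker inhibition. Compound 1 `C[Si](C)(C)c1cn(C[C@H](O)[C@H]2OC(=O)C(OCc3ccccc3)=C2OCc2ccccc2)nn1` gives 52600 nM. Compound 2 `O=C1O[C@H]([C@@H](O)Cn2cc(-c3cc(C(F)(F)F)cc(C(F)(F)F)c3)nn2)C(OCc2ccccc2)=C1OCc1ccccc1` gives 66500 nM; the two numbers lie within the usual scatter of each other, so compound 1 carries the lowest of the two numbers without standing apart from compound 2. Compound 3 `O=C1O/C(=C\Cn2cc(-c3cc(C(F)(F)F)cc(C(F)(F)F)c3)nn2)C(OCc2ccccc2)=C1OCc1ccccc1` gives > 100000 nM, which is a limit of the assay and not a number. The position of that limit is the limit of > 100000 nM in this assay, at which 1 of the 3 values shown sits.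

Compound 4 `O=C1O[C@H]([C@@H](O)Cn2cc(CCCCl)nn2)C(OCc2ccccc2)=C1OCc1ccccc1` has not yet been measured. Compared with compound 1 it shows one change: a group of 4 heavy atoms (3 carbon, 1 chlorine; no ring) in place of a group of 4 heavy atoms (3 carbon, 1 silicon; no ring), on an aromatic carbon. Among the compounds with values here, no step between two measured compounds that differ in a single place is available, so the effect of this change can be judged only from the level set by compound 1 and compound 2. In this assay no step beyond the scatter is expected in either direction. Compound 4 is therefore estimated at 55000 nM, with a range from 20000 nM to 150000 nM. That estimate means a step of a 1.0-fold higher number from compound 1 to compound 4 (0.02 log units; within the scatter) that stays inside the scatter.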

Compound 4, half-maximal inhibitory concentration: 58800 nM
The estimate for compound 4 lay 1.1-fold (0.03 log units) below the measured number; the range from low to high includes it.
By their numbers in this assay, from the lowest: compounds 1, 4 and 2 (each within the scatter of the next). At a limit, above all of these: compound 3.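

In this assay, within the data shown here, the single change gives a 1.1-fold higher number from compound 1 to compound 4 (0.05 log units; within the scatter). Among these compounds, at this place on the five-membered aromatic ring with 3 nitrogen, 3-chloropropyl and the group of 3 carbon and 1 silicon therefore cannot be told apart, something the earlier compounds could not show, since no two of them with a printed step differed in one place only. Compound 3 still stands at a limit, which is not a number: the limit of > 100000 nM in this assay, at which 1 of the 4 values shown sits.

As far as these compounds go, both groups compared here have no ring, no hydrogen-bond donors and no hydrogen-bond acceptors, and it stays open whether an amine, a carboxylic acid or a longer chain at this place would give a step beyond the scatter. From the compounds shown here alone, it also stays open whether the same swap would read the same way on other cell lines.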